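A few compounds are considered here, and "the series" means these few. Any claim that something is new, unique, unknown or untested is made for them only; others in the source may bear on it.

Measured so far:
compound 1, `O=C(/C=C/c1ccc(O)cc1)c1c(O)cccc1OCC1CCCCC1`: > 30000 nM
compound 2, `COc1cccc(OCCC(C)(C)C)c1C(=O)/C=C/c1ccc(O)cc1`: > 30000 nM

Both compounds were tested in a functional assay on MDA-MB-231 cells (Homo sapiens) for antiproliferative activity, read by sulforhodamine B assay; a higher number here means a weaker inhibitor of growth, a lower number a stronger inhibitor of growth. In this assay compound 1 gives > 30000 nM, which is a limit of the assay and not a number. Compound 2 likewise gives > 30000 nM, again only a limit. Among the measured compounds shown here, compound 1 therefore stands at the limit of > 30000 nM in this assay, at which 2 of the 2 values shown sit; no numerical value exists anywhere in the set, and no step between measured compounds can be read.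

Compound 3, `O=C(/C=C/c1ccc(O)cc1)c1c(O)cccc1OCc1ccccc1`, remains to be measured in this assay. It differs from compound 1 by phenyl in place of cyclohexyl on a saturated chain carbon bound to an oxygen on an aromatic ring. Without any measured step to lean on, the expectation rests on compound 1 sitting at the limit: the change is expected to leave growth inhibition weak, with any movement in this assay within the usual scatter or at most a modest gain toward stronger inhibition. The expected step is a number no higher from compound 1 to compound 3 (the limit leaves the size open). Compound 3 is expected to give about 30000 nM in this assay, with a range from 8000 nM to 100000 nM, and a substantial chance that once more only a limit is reported.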

Compound 3, concentration for 50% growth inhibition: > 30000 nM
Compound 3 ended at the assay's limit; the forecaster's own chance of this, stated with the estimate: 65%; the middle value sits exactly at the limit.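

No step can be read between compound 1 and compound 3 in this assay, as neither compound has a numerical value: the limit of > 30000 nM in this assay, at which 3 of the 3 values shown sit.

The compounds shown leave open how far each lies beyond that limit, and whether phenyl in place of cyclohexyl changes growth inhibition at all.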